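Aryl ketone change on the vinyl sulfide enone series

This account rests on a few compounds, and the source may have more. Where it says the series, first, only, none or still open, it means among the compounds named here.

The shared core holds an aryl ketone, a vinyl sulfide and an arylidene arm. Compound 1 `O=C(/C(=C\c1ccc(O)cc1)SCc1ccc(Cl)cc1)c1ccc(Br)cc1`, compound 2 `O=C(/C(=C\c1ccc(Cl)cc1)Sc1ccc(Br)cc1)c1ccc(Br)cc1` and compound 3 `O=C(/C(=C\c1ccc([N+](=O)[O-])c(O)c1)SCc1ccc(Br)cc1)c1ccc(Br)cc1` have been run in a functional assay on DU-145 cells (Homo sapiens) for inhibition, read by trypan blue exclusion, with a stated time of 96 h; on this read-out lower numbers stand for stronger inhibition of growth and higher numbers for weaker inhibition of growth. Compound 1 gives 10000 nM, compound 2 gives 1000 nM and compound 3 gives 10000 nM. Compound 3 stands level with compound 1 at the digits shown, the two together at the highest number of the three, while compound 2 sits at a lower number, beyond the scatter. Compound 4 `O=C(/C(=C\c1ccc([N+](=O)[O-])c(O)c1)SCc1ccc(Br)cc1)c1cc(Cl)ccc1O` differs from compound 3 in one place: 5-chloro-2-hydroxyphenyl in place of 4-bromophenyl on a carbonyl carbon. Among the measured compounds shown here, no measured pair shows this kind of change, so its direction is unknown; in this assay the step from compound 3 to compound 4 is expected to be no change at the digits printed from compound 3 to compound 4 (within the scatter), probably within the scatter. Compound 4 is therefore estimated at 10000 nM, with a range from 3000 nM to 30000 nM.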

Compound 4, concentration for 50% growth inhibition: 10000 nM
The estimate for compound 4 equals the measured number at the digits printed, and the stated range covers the measured number.
By their numbers in this assay, from the lowest: compound 2; then compounds 1, 3 and 4 (each within the scatter of the next).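

Among the compounds shown here, on a carbonyl carbon, 5-chloro-2-hydroxyphenyl in place of 4-bromophenyl gives no change at the digits printed from compound 3 to compound 4 (within the scatter) in this assay and is the first single-place step. With the rest of compound 3 held constant, this position accepts one added hydrogen-bond donor and one added acceptor without a step beyond the scatter. No available evidence bears on the reason for this result.

Going by these compounds, it remains open whether the same change would hold on the lower-valued compound 2. Also unresolved is how an aminophenyl or carboxylic acid group would read at this carbonyl carbon.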